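From thiophen-2-yl to 2-methoxypyridin-4-yl on the shared core

The source may report more compounds than this note shows. Statements on the series, on what has been measured and on what is new or still open speak of the compounds shown alone.

Measured in a functional assay on HL-60 cells (Homo sapiens) for cytotoxicity, read by CellTiter-Blue, with a stated time of 48 h; a higher number here means a weaker inhibitor, a lower number a stronger inhibitor:
- compound 1 `CCOC(=O)CC1C(C(=O)OC)=C(N)Oc2ccc(-c3cc(OC)cc(OC)c3)cc21`: 10800 nM
- compound 2 `CCOC(=O)CC1C(C(=O)OCC)=C(N)Oc2ccc(-c3ccco3)cc21`: > 80000 nM (a limit)
- compound 3 `CCOC(=O)CC1C(C(=O)OCC)=C(N)Oc2ccc(-c3cccs3)cc21`: > 80000 nM (a limit)

Compound 3 has no number, only a limit: the limit of > 80000 nM in this assay, at which 2 of the 3 values shown sit. The next change gives compound 4 `CCOC(=O)CC1C(C(=O)OCC)=C(N)Oc2ccc(-c3ccnc(OC)c3)cc21`, with 2-methoxypyridin-4-yl in place of thiophen-2-yl on an aromatic carbon. For the measured compounds named here, the one measured single change is a step that the two limits leave unreadable from compound 2 to compound 3, and it offers no size to carry over. Going by the values given here, compound 1 gives 10800 nM, the only number here, and it also carries a six-membered aromatic ring, though it differs elsewhere too. A modest shift towards stronger inhibition in this assay is therefore expected, with low confidence. The expected step is an at least 2.6-fold lower number from compound 3 to compound 4 (0.42 log units; beyond the scatter). For compound 4 the estimated value is 30000 nM, with an expected range of 9000 nM to 80000 nM.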

Compound 4, half-maximal inhibitory concentration: 10200 nM
Compound 4: middle estimate off by 2.9-fold (0.47 log units), on the high side, within the range that was stated.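

In this assay, this position on the shared core now gives a readable change: 2-methoxypyridin-4-yl in place of thiophen-2-yl gives an at least 7.8-fold lower number from compound 3 to compound 4 (0.89 log units; beyond the scatter), and in place of furan-2-yl gives an at least 7.8-fold lower number from compound 2 to compound 4 (0.89 log units; beyond the scatter). On these data alone, the true sizes of both steps remain unknown, and the step between the two five-membered aromatic rings cannot be read. Compound 2 and compound 3 each carry only a limit: the limit of > 80000 nM in this assay, at which 2 of the 4 values shown sit.

As far as these compounds go, it remains open whether the ring nitrogen or the methoxy group carries the change. A plain pyridin-4-yl or a 2-aminopyridin-4-yl at this position would separate the two.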